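The compounds below may be only part of what the source reports. "The series", "measured", "known", "first", "only" and "open" are said of these compounds alone.

Measured so far in an assay on a protein complex for inhibition of CDK8/Cyclin C (Homo sapiens), with a stated time of 1 h, tested at 10 uM; a higher number here means more inhibition at the concentration tested (going by the name of the read-out), a lower number less inhibition:

compound 1, `CNC(=O)COc1ccncc1-c1ccc2ccccc2c1`, gives 4%
compound 2, `O=C(COc1ccncc1-c1ccc2ccccc2c1)N1CCOCC1`, gives 9%

Both numbers are small. On paper compound 1 has the smaller of the two, but the step of a number 5 percentage points higher from compound 1 to compound 2 (within the scatter) lies within the usual scatter, so the two compounds cannot be told apart on these data.

The next compound, compound 3, is `COC(=O)CCc1ccncc1-c1ccc2ccccc2c1`. Compared with compound 1 the change is 2-(methoxycarbonyl)ethyl in place of (methylcarbamoyl)methoxy on an aromatic carbon. Going by the values given here, no measured step covers this exact change; the only step available, from compound 1 to compound 2, altered the group on the carbonyl carbon, morpholin-4-yl in place of methylamino, and gave a number 5 percentage points higher from compound 1 to compound 2 (within the scatter), no movement beyond the scatter. Among the compounds with values here, with only two low numbers in hand, the expectation is that compound 3 will also stay low, and the step of a number 2 percentage points higher from compound 1 to compound 3 (within the scatter) is expected to be within the scatter. Compound 3 is therefore estimated at 6%, with a range from -5% to 20%.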

Compound 3, a percentage reported as inhibition, at one concentration (the size of the read-out at that concentration, not a potency): 98%
Estimate against measurement, compound 3: 92 percentage points below; measured number outside the range, above it.
By their numbers in this assay, from the lowest: compounds 1 and 2 (each within the scatter of the next); then compound 3.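

In this assay, the position on the six-membered aromatic ring opposite the ring nitrogen responds far more strongly than the group on the carbonyl carbon did: 2-(methoxycarbonyl)ethyl in place of (methylcarbamoyl)methoxy gives a number 94 percentage points higher from compound 1 to compound 3 (beyond the scatter), a jump made without any change in the heavy-atom count. By the counts, the entering group has one more carbon, no nitrogen and no hydrogen-bond donor, and neither group has a ring. No measurement at hand says which of these differences matters, or why the number rises.

Compound 3 changes both the chain attached to the ring and the group at its end, so the two contributions remain unseparated. A carboxylic acid or a methylamide on the same ethyl chain, or a longer chain carrying the methoxycarbonyl group, would help to tell them apart.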